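The source may report more compounds than this note shows. Statements on the series, on what has been measured and on what is new or still open speak of the compounds shown alone.

Measured so far in an ADME assay on MCF-10A cells (Homo sapiens) for inhibition, read by MTT assay, with a stated time of 48 h, tested at 2 uM; on this read-out higher numbers stand for more inhibition at the one concentration tested (going by the name of the read-out) and lower numbers for less inhibition:

compound 1, `Cc1noc(C)c1-c1ccc2c(c1)C(c1ccccc1)N(Cc1nnc(-c3ccccc3)s1)C(=O)N2C`: 3.3%
compound 2, `Cc1noc(C)c1-c1ccc2c(c1)C(c1ccccc1)N(Cc1nc(-c3ccccc3)cs1)C(=O)N2C`: 2.7%

Both compounds share one core, and both barely inhibit growth at the single concentration tested. On the two numbers shown, compound 2 stands at the smaller figure, yet the step of a number 0.6 percentage points lower from compound 1 to compound 2 (within the scatter) is within the scatter, so the two compounds cannot be told apart. That step exchanged one five-membered aromatic ring with 2 hetero atoms for another on the saturated chain carbon bound to the amide-type nitrogen in the ring, and it changed nothing beyond the scatter.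

Compound 3, `Cc1noc(C)c1-c1ccc2c(c1)C(c1ccccc1)N(Cc1csc(-c3ccc(F)cc3)n1)C(=O)N2C`, is the next member. Compared with compound 2, the change is 2-(4-fluorophenyl)-1,3-thiazol-4-yl in place of 4-phenyl-1,3-thiazol-2-yl on a saturated chain carbon bound to an amide-type nitrogen in a ring. Within the data shown here, the only measured step that bears on this place, a number 0.6 percentage points lower from compound 1 to compound 2 (within the scatter), was within the scatter, and the new change again swaps one five-membered aromatic ring with 2 hetero atoms for a related one, adding a fluorine. No step beyond the scatter is therefore expected, and compound 3 is estimated at 4%, between -5% and 15%. The expected step is a number 1.3 percentage points higher from compound 2 to compound 3 (within the scatter).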

Compound 3, a percentage reported as inhibition, at one concentration (the size of the read-out at that concentration, not a potency): 6.8%
Compound 3: the middle estimate sits 2.8 percentage points below what was measured; low and high end bracket the measured number.
By their numbers in this assay, from the lowest: compounds 2, 1 and 3 (each within the scatter of the next).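

In this assay the step is a number 4.1 percentage points higher from compound 2 to compound 3 (within the scatter) and the other step is a number 3.5 percentage points higher from compound 1 to compound 3 (within the scatter) so the place on a saturated chain carbon bound to an amide-type nitrogen in a ring has now taken a third ring group, this one carrying a fluorine, with no change beyond the scatter. The new group, 2-(4-fluorophenyl)-1,3-thiazol-4-yl, differs from 4-phenyl-1,3-thiazol-2-yl both in its fluorine and in how its thiazole is joined, so these two changes cannot be separated here. No measurement at hand offers an explanation for these small differences.

From the compounds shown here alone, all three groups are phenyl-bearing five-membered aromatic rings, so it remains open whether any group at this place moves the number beyond the scatter. An amine or a carboxylic acid on the phenyl ring, or a plain longer carbon chain in place of the rings, would be a different kind of test.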